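Swapping phenyl for bromopyridinyl on a sulfonamide nitrogen

The source may hold more compounds than are shown below. What is called first, only, known or untested is meant among the compounds shown, and "the series" means these compounds.

Measured compounds:
compound 1 `O=S(=O)(CSc1nnc(Br)n1Cc1ccc(Br)c2ccccc12)Nc1ccccc1` gives 15800 nM in an assay on HEK293 cells for inhibition of solute carrier family 22 member 12 (Homo sapiens); a higher number here means a weaker inhibitor, a lower number a stronger inhibitor
compound 2 `O=S(=O)(CSc1nnc(Br)n1Cc1ccc(Br)c2ccccc12)Nc1cc(Cl)cnc1Cl` gives 2790 nM in this assay
compound 3 `O=S(=O)(CSc1nnc(Br)n1Cc1ccc(Br)c2ccccc12)Nc1ccc(Cl)nc1Cl` gives 1660 nM in this assay

Compound 1 gives the highest number of the three, so it is the weakest inhibitor among those measured. Compound 4 `O=S(=O)(CSc1nnc(Br)n1Cc1ccc(Br)c2ccccc12)Nc1ccc(Br)nc1` differs from it in one place: 6-bromopyridin-3-yl in place of phenyl on a sulfonamide nitrogen. Within the data shown here, two measured steps bear on this change: a 5.7-fold lower number from compound 1 to compound 2 (0.75 log units; beyond the scatter) and a 9.5-fold lower number from compound 1 to compound 3 (0.98 log units; beyond the scatter), both modest gains when a dichloropyridinyl replaces the phenyl. The bromopyridinyl entering compound 4 is related to those groups, so a gain of similar or somewhat smaller size is expected. Compound 4 is therefore expected to show a 3.2-fold lower number from compound 1 to compound 4 (0.50 log units; beyond the scatter), giving an estimated 5000 nM with a range from 2000 nM to 13000 nM.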

Compound 4, half-maximal inhibitory concentration: 2200 nM
Estimate against measurement, compound 4: 2.3-fold (0.36 log units) above, within the range that was stated.
By their numbers in this assay, from the lowest: compounds 3, 4 and 2 (each within the scatter of the next); then compound 1.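

With 6-bromopyridin-3-yl on the sulfonamide nitrogen, this assay shows a 7.2-fold lower number from compound 1 to compound 4 (0.86 log units; beyond the scatter) and so the gain over phenyl does not require two chlorines. This group also matches both dichloropyridinyl groups, with a 1.3-fold higher number from compound 3 to compound 4 (0.12 log units; within the scatter) and a 1.3-fold lower number from compound 2 to compound 4 (0.10 log units; within the scatter) so these three replacements cannot be ranked here. Nothing available explains why these rings outperform phenyl. The compounds shown leave open whether a plain pyridin-3-yl ring, carrying no halogen, would keep this gain. They also leave open what an amine or a carboxylic acid in place of the bromine would do.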